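Aryl exchange on the shared core: compound 2 to compound 3

This account rests on a few compounds, and the source may have more. Where it says the series, first, only, none or still open, it means among the compounds named here.

Measured in a functional assay on B16-F10 cells (Mus musculus) for antiproliferative activity, read by MTT assay, with a stated time of 48 h; on this read-out lower numbers stand for stronger inhibition and higher numbers for weaker inhibition:
- compound 1 `O=C(/C=C/c1ccc(O)c(O)c1)N1CCN(c2ccccc2F)CC1`: 2.43 ug/mL
- compound 2 `COc1cccc(N2CCN(C(=O)/C=C/c3ccc(O)c(O)c3)CC2)c1`: 1.46 ug/mL

Compound 2 at 1.46 ug/mL stands within the scatter of compound 1 at 2.43 ug/mL. Compound 3 `Cc1ccc(N2CCN(C(=O)/C=C/c3ccc(O)c(O)c3)CC2)c(C)c1` carries 2,4-dimethylphenyl in place of 3-methoxyphenyl on an amine nitrogen in a ring. For the measured compounds named here, one measured step bears on this, an exchange on the same nitrogen: a 1.7-fold lower number from compound 1 to compound 2 (0.22 log units; within the scatter). No step beyond the scatter is therefore expected in this assay. The expected change is a 1.3-fold higher number from compound 2 to compound 3 (0.11 log units; within the scatter). For compound 3 the estimated value is 1.9 ug/mL, with an expected range of 0.8 ug/mL to 4.5 ug/mL.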

Compound 3, half-maximal inhibitory concentration: 1.43 ug/mL
Compound 3: middle estimate off by 1.3-fold (0.12 log units), on the high side; low and high end bracket the measured number.
By their numbers in this assay, from the lowest: compounds 3, 2 and 1 (each within the scatter of the next).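

In this assay the exchange of 3-methoxyphenyl for the all-carbon 2,4-dimethylphenyl gives a 1.0-fold lower number from compound 2 to compound 3 (0.01 log units; within the scatter) and so leaves the number in place, even though the methoxy oxygen is gone. The exchange of 2-fluorophenyl for 2,4-dimethylphenyl gives a 1.7-fold lower number from compound 1 to compound 3 (0.23 log units; within the scatter) and also stays within the scatter, so all three aryl groups on this ring nitrogen now read alike. No measured evidence bears on these steps. Still open, as far as these compounds go, is whether a group other than a substituted phenyl on this nitrogen, such as a chain bearing an amine or a phenyl bearing a carboxylic acid, would give a step beyond the scatter.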